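Propanoyl on the sulfonamide nitrogen of compound 2

The compounds below may be only part of what the source reports. "The series", "measured", "known", "first", "only" and "open" are said of these compounds alone.

In a functional assay on the whole organism (strain Wistar) with Rattus norvegicus as the target, read by paw edema, at a dose of 30 mg/kg by the oral route (on this read-out lower numbers stand for an effect already at smaller amounts and higher numbers for an effect only at larger amounts of compound), compound 1 `CCC(=O)NS(=O)(=O)c1ccc(-n2nc(C(F)(F)F)cc2-c2ccc(Br)cc2)cc1COC(=O)CC` gives 37 mg/kg. Compound 2 `CCC(=O)OCc1cc(-n2nc(C(F)F)cc2-c2ccc(Br)cc2)ccc1S(N)(=O)=O` gives 40 mg/kg, and these two numbers lie within the scatter of each other. Among the compounds with values here, compound 2 therefore stands level with compound 1 on the only two numbers available, and neither can be ranked.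

The next compound to read is compound 3 `CCC(=O)NS(=O)(=O)c1ccc(-n2nc(C(F)F)cc2-c2ccc(Br)cc2)cc1COC(=O)CC`. It differs from compound 2 by propanoyl in place of hydrogen on a sulfonamide nitrogen, which places propanoyl in place of hydrogen on a sulfonamide nitrogen. Within the data shown here, no measured pair isolates this change, so the data give no direct size or direction for it.

Among the measured compounds shown here, with compound 1 at 37 mg/kg and compound 2 at 40 mg/kg, the numbers so far show no spread beyond the scatter, and a shift beyond the scatter in this assay is not expected. The expected change, a 1.1-fold lower number from compound 2 to compound 3 (0.02 log units; within the scatter), is therefore small, with no direction favoured. For compound 3 the estimate is 38 mg/kg, with an expected range of 19 mg/kg to 75 mg/kg.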

Compound 3, dose for half-maximal effect: 45 mg/kg
Compound 3: the middle estimate sits 1.2-fold (0.07 log units) below what was measured; measured number inside the range.
By their numbers in this assay, from the lowest: compounds 1, 2 and 3 (each within the scatter of the next).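

In this assay the propanoyl in place of hydrogen on a sulfonamide nitrogen now has a direct reading, with a 1.1-fold higher number from compound 2 to compound 3 (0.05 log units; within the scatter) as its step, so on these numbers the amino and propanoylamino forms of this nitrogen cannot be told apart. The second single-place pair, hydrogen in place of fluoro on a saturated chain carbon bound to an aromatic carbon and two fluorine atoms, gives a 1.2-fold higher number from compound 1 to compound 3 (0.09 log units; within the scatter) and likewise separates nothing, so neither place has yet shown a step that stands out from the scatter. No measurement available here bears on why these steps are so small.

On these data alone, each place has been read with one change only, so whether an acetyl group or a longer acyl chain on the sulfonamide nitrogen would move the number beyond the scatter remains open. Also open, as far as these compounds go, is whether a methyl group at the fluorinated chain carbon would separate from these compounds, and whether any step at either place would hold on a different core.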